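A few compounds are considered here, and "the series" means these few. Any claim that something is new, unique, unknown or untested is made for them only; others in the source may bear on it.

Of the compounds shown here, three have been measured in a functional assay on HOP-62 cells (Homo sapiens) for inhibition; a lower number here means a stronger inhibitor of growth, a higher number a weaker inhibitor of growth. Compound 1 `CC(=O)CC/C=C(\C)CCC1=C(C)CCCC1(C)C` is an open-chain ketone, and in this assay compound 1 reaches only a limit, > 15000 nM. Compound 2 `COC(=O)[C@H](C)[C@H]1CC[C@@](C)(CCC2=C(C)CCCC2(C)C)OO1` carries a methyl ester on a cyclic peroxide, and in this assay compound 2 likewise reaches only a limit, > 25000 nM. Going by the values given here, compound 3 `C=C1CCCC(C)(C)C1CC[C@@]1(C)CC[C@H]([C@@H](C)C(=O)O)OO1` bears a free carboxylic acid on a cyclic peroxide, and in this assay compound 3 gives 2110 nM, the only actual number among the three. For compound 1 the value is a limit, namely (the limit of > 15000 nM in this assay, at which 1 of the 3 values shown sits). For compound 2 the value is a limit, namely (the limit of > 25000 nM in this assay, at which 1 of the 3 values shown sits).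

Compound 4 `C=C1CCCC(C)(C)C1CC[C@]1(C)CC[C@@H]([C@@H](C)C(=O)O)OO1` has not yet been measured. It differs from compound 3 in this way: the two compounds have the same atoms and bonds; at least one stereo element is drawn with a configuration in one of them and without one in the other: 2 of 4 stereo elements differ; a stereocentre at a saturated ring carbon is drawn S in compound 3 and R in compound 4; a stereocentre at a saturated ring carbon is drawn R in compound 3 and S in compound 4. Among the compounds with values here, no measured pair shows what such a swap of stereocentres alone does. With the atoms and bonds unchanged, a modest shift in either direction, possibly no larger than the scatter, is expected. Compound 4 is therefore expected to give about 3000 nM, somewhere between 800 nM and 12000 nM. The expected step of a 1.4-fold higher number from compound 3 to compound 4 (0.15 log units; within the scatter) is accordingly small.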

Compound 4, concentration for 50% growth inhibition: 9540 nM
Estimate against measurement, compound 4: 3.2-fold (0.50 log units) below, and the stated range covers the measured number.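

In this assay, going by these compounds alone, the swap of drawn configuration at two saturated ring carbons, with atoms and bonds unchanged, gives a 4.5-fold higher number from compound 3 to compound 4 (0.66 log units; beyond the scatter) and so shows what no earlier pair could: the arrangement in space at these carbons alone moves the number beyond the scatter. Even so, compound 4, like compound 3, gives an actual number rather than a limit, so the swap weakens growth inhibition without removing it. The only structural ground on record for the step is this: the fact that one of compounds 3 and 4 is drawn with a defined configuration and the other without, at the place where they differ.

Going by these compounds, the two stereocentres change together here, so the share of each in the step stays open. Also open, on these data alone, is whether an amide or a primary alcohol in place of the carboxylic acid would keep the same preference for one arrangement.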